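A few compounds are considered here, and "the series" means these few. Any claim that something is new, unique, unknown or untested is made for them only; others in the source may bear on it.

The shared core carries a small group on its fused aromatic ring, and that position is varied across the set. Compound 2 `Cc1ccc2nc(C(=O)Nc3c(F)cc(-c4cccc(F)c4)cc3F)c(C)c(C(=O)O)c2c1` has a methyl there, and in a functional assay on Hep 3B2 cells (Homo sapiens) for antiproliferative activity, read by MTT assay, with a stated time of 24 h, tested at 1.23 ug/mL (on this read-out higher numbers stand for a stronger effect at the one concentration tested and lower numbers for a weaker effect), compound 2 gives 21.3%. Compound 3 `Cc1c(C(=O)Nc2c(F)cc(-c3cccc(F)c3)cc2F)nc2ccc(F)cc2c1C(=O)O` has a fluoro instead, and in this assay compound 3 gives 2.45%. Compound 1 `CCOc1ccc2nc(C(=O)Nc3c(F)cc(-c4cccc(F)c4)cc3F)c(C)c(O)c2c1` carries an ethoxy but differs from the others in a second place as well; in this assay compound 1 gives 1.03%. Among the three measured numbers compound 3 stands second highest, though its gap to compound 1 is within the scatter, while its gap to compound 2 is beyond it.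

Compound 4 `CCOc1ccc2nc(C(=O)Nc3c(F)cc(-c4cccc(F)c4)cc3F)c(C)c(C(=O)O)c2c1` changes compound 3 in one place: ethoxy in place of fluoro on an aromatic carbon.

Going by the values given here, only one measured step touches this same position, a number 18.9 percentage points lower from compound 2 to compound 3 (beyond the scatter), a modest drop. Among the compounds with values here, no measured step puts an ethoxy in place of a fluoro, and compound 1 does not offer a single-change comparison, so the direction for compound 4 rests on thin ground. Because compound 2 gives 21.3% with a carbon group at this position, compound 4 is expected to rise somewhat, a number 7.6 percentage points higher from compound 3 to compound 4 (within the scatter), though a result within the scatter would not surprise. Compound 4 is estimated at 10%, with a range from 0% to 28%.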

Compound 4, a percentage reported as inhibition, at one concentration (the size of the read-out at that concentration, not a potency): 17.9%
For compound 4 the middle estimate is 7.9 percentage points below the measured one; the range from low to high includes it.
By their numbers in this assay, from the lowest: compounds 1 and 3 (each within the scatter of the next); then compounds 4 and 2 (each within the scatter of the next).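

In this assay the ethoxy group brings the reading back up from the fluoro compound, with a number 15.5 percentage points higher from compound 3 to compound 4 (beyond the scatter) for this change on the aromatic carbon. Set against the methyl group, the step is a number 3.4 percentage points lower from compound 2 to compound 4 (within the scatter) and so ethoxy and methyl cannot be told apart here, which leaves fluoro as the one group of the three whose compound reads lower than the other two. Going by these compounds alone, compound 4 also supplies the first single-change comparison for compound 1, with a number 16.9 percentage points higher from compound 1 to compound 4 (beyond the scatter) when carboxy replaces hydroxy, so the low reading of compound 1 goes with the hydroxy group and not with the ethoxy group it carries; nothing at hand explains any of these differences.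

From the compounds shown here alone, it remains open whether an amine or a longer chain such as butoxy at this position would read like methyl and ethoxy or like fluoro. Going by these compounds, each number is also the size of an effect at one concentration, so whether these compounds would show a stronger or weaker effect at other concentrations stays open.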